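Cytotoxicity of two aryloxyphenoxyacetamide sulfonamides and a third

The source may hold more compounds than are shown below. What is called first, only, known or untested is meant among the compounds shown, and "the series" means these compounds.

Measured compounds:
compound 1 `Cc1cc(S(N)(=O)=O)ccc1NC(=O)COc1ccc(F)cc1Oc1cc2ccccc2cc1C`, 66900 nM
compound 2 `Cc1cc(S(N)(=O)=O)ccc1NC(=O)COc1ccc(F)cc1Oc1ccc2cc(Br)ccc2c1Cl`, 195000 nM

In an ADME assay on C8166 cells (Homo sapiens) for cytotoxicity, read by MTT assay (a higher number here means that more compound is tolerated, a lower number that less compound is tolerated), compound 2 gives the higher of the two numbers; compound 1 gives 66900 nM, and a 2.9-fold higher number from compound 1 to compound 2 (0.46 log units; beyond the scatter). Compound 3 `Cc1cc(S(N)(=O)=O)ccc1NC(=O)COc1ccc(F)cc1Oc1c(C)cc2ccccc2c1Cl` is not yet measured. It differs from compound 2 by 1-chloro-3-methylnaphthalen-2-yl in place of 6-bromo-1-chloronaphthalen-2-yl on an oxygen on an aromatic ring. Within the data shown here, only the step from compound 1 to compound 2 bears on this, and it was modest. The change to compound 3 removes the bromine while keeping the chlorine, so a modest drop toward compound 1 is expected: for compound 3 the estimate is 110000 nM, range 45000 nM to 270000 nM, meaning an expected step of a 1.8-fold lower number from compound 2 to compound 3 (0.25 log units; within the scatter).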

Compound 3, half-maximal cytotoxic concentration: 55600 nM
The estimate for compound 3 lay 2.0-fold (0.30 log units) above the measured number; low and high end bracket the measured number.
By their numbers in this assay, from the lowest: compounds 3 and 1 (each within the scatter of the next); then compound 2.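

In this assay, chloro in place of hydrogen on an aromatic carbon gives a 1.2-fold lower number from compound 1 to compound 3 (0.08 log units; within the scatter), so this chlorine by itself does not bring the number to that of compound 2. Keeping the chlorine and exchanging the rest of the substituent, 1-chloro-3-methylnaphthalen-2-yl in place of 6-bromo-1-chloronaphthalen-2-yl, gives a 3.5-fold lower number from compound 2 to compound 3 (0.54 log units; beyond the scatter). No evidence is at hand to explain this step.

The compounds shown do not separate the loss of the bromine from the gain of the methyl. Going by these compounds, how an amine or a carboxylic acid on this naphthalene would read also stays open.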